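The source may report more compounds than this note shows. Statements on the series, on what has been measured and on what is new or still open speak of the compounds shown alone.

Measured so far in a functional assay on KB cells (Homo sapiens) for cytotoxicity, read by MTT assay, with a stated time of 48 h; on this read-out higher numbers stand for weaker inhibition and lower numbers for stronger inhibition:
- compound 1 `CCn1cc(-c2nc3ccccc3[nH]2)c(=O)c2cc(F)c(N3CCNC(C)C3)c(F)c21` gives 19100 nM
- compound 2 `CCn1cc(-c2nc3ccccc3o2)c(=O)c2cc(F)c(N3CCNC(C)C3)c(F)c21` gives 18900 nM

Compound 2 has a single measured neighbour, compound 1, and the two values lie within the scatter of each other. Compound 3 `CCn1cc(-c2nc3ccc([N+](=O)[O-])cc3o2)c(=O)c2cc(F)c(N3CCNC(C)C3)c(F)c21` has not yet been measured. It is compound 2 with nitro in place of hydrogen on an aromatic carbon of a six-membered aromatic ring of carbon only, part of a fused or bridged system of two rings.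

Among the measured compounds shown here, only one measured step bears on this, and only loosely. The step of a 1.0-fold lower number from compound 1 to compound 2 (0.00 log units; within the scatter) came from 1,3-benzoxazol-2-yl in place of 1H-benzimidazol-2-yl. For the measured compounds named here, no measured step adds a nitro, so the data give no direct size for this change. A cautious expectation in this assay is therefore a small move toward a lower number, and it may not clear the scatter. The estimated step is a 1.5-fold lower number from compound 2 to compound 3 (0.16 log units; within the scatter) and it remains a rough guess. For compound 3 the estimate is 13000 nM with an expected range from 5000 nM to 30000 nM in this wide band.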

Compound 3, half-maximal inhibitory concentration: 600 nM
Beside the measured number, compound 3's estimate is 22-fold (1.34 log units) above it; measured number outside the range, below it.
By their numbers in this assay, from the lowest: compound 3; then compounds 2 and 1 (each within the scatter of the next).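

The earlier pair gave no sign that this part of the molecule mattered, since 1,3-benzoxazol-2-yl in place of 1H-benzimidazol-2-yl gave a 1.0-fold lower number from compound 1 to compound 2 (0.00 log units; within the scatter) in this assay. Nitro in place of hydrogen on the six-membered aromatic ring of carbon only gives a 32-fold lower number from compound 2 to compound 3 (1.50 log units; beyond the scatter) and so shows that the read-out responds strongly to a change at this carbon, even though the rest of the structure stays the same. The change adds only 3 heavy atoms, so a small addition to this ring is enough to produce a large shift in cytotoxicity. Nothing measured here explains why this nitro has such an effect.

With only nitro shown at this carbon, it remains open whether the shift is specific to nitro or would also appear with another group there, such as an amine, a methoxy group or a chlorine atom. From the compounds shown here alone, it is also open whether nitro at the matching carbon of compound 1 would give a similar step, or whether the step depends on the 1,3-benzoxazol-2-yl group of compound 2.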